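This account rests on a few compounds, and the source may have more. Where it says the series, first, only, none or still open, it means among the compounds named here.

Compound 1 `C[C@@H]1CC(=O)Nc2ncnc(N3CCC(c4nc(C(F)(F)F)cn4CCN4CCCC4)CC3)c21`: 1860 ug/mL
Compound 2 `C[C@@H]1CC(=O)Nc2ncnc(N3CCC(c4nc(C5CCOCC5)cn4CCN4CCCC4)CC3)c21`: > 2000 ug/mL

In a physicochemical assay for solubility, at pH 7.4 (a higher number here means a more soluble compound, a lower number a less soluble compound), compound 2 gives > 2000 ug/mL, which is a limit of the assay and not a number. The next compound, compound 3 `C[C@@H]1CC(=O)Nc2ncnc(N3CCC(c4nc(CCC(F)(F)F)cn4CCN4CCCC4)CC3)c21`, differs from it by one change, 3,3,3-trifluoropropyl in place of oxan-4-yl on an aromatic carbon. Within the data shown here, only one measured step bears on this position, an at least 1.0-fold higher number from compound 1 to compound 2 (0.03 log units; that floor lies within the scatter), with oxan-4-yl in place of trifluoromethyl. That step stays within the scatter, so swapping these groups has not yet moved this assay measurably. Compound 1, the fluorine-bearing comparison, gives 1860 ug/mL. A small step is therefore expected, downward if it shows at all. The expected step is an at least 1.1-fold lower number from compound 2 to compound 3 (0.07 log units; that floor lies within the scatter). Compound 3 is estimated at 1700 ug/mL, with an expected range of 900 ug/mL to 2000 ug/mL.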

Compound 3, solubility: 990 ug/mL
Compound 3: the middle estimate sits 1.7-fold (0.23 log units) above what was measured, within the range that was stated.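

In this assay, 3,3,3-trifluoropropyl in place of trifluoromethyl gives a 1.9-fold lower number from compound 1 to compound 3 (0.27 log units; within the scatter), so this position has now given two exact numbers, and the step between them does not clear the usual scatter. Putting the open chain, with no hydrogen-bond acceptor, in place of the oxan-4-yl ring, which has one, gives an at least 2.0-fold lower number from compound 2 to compound 3 (0.30 log units; that floor lies within the scatter). The true size of that step remains unknown because compound 2 sits at a limit and not at a number: the limit of > 2000 ug/mL in this assay, at which 1 of the 3 values shown sits.

Going by these compounds, it remains open how far this assay would move with an amine or a carboxylic acid on this aromatic carbon. Also open, on these data alone, is whether a tetrahydrofuranyl ring or a plain pentyl chain would behave more like oxan-4-yl or like 3,3,3-trifluoropropyl.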